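The source may hold more compounds than are shown below. What is called first, only, known or untested is meant among the compounds shown, and "the series" means these compounds.

In an ADME assay on MRC5 cells (Homo sapiens) for inhibition, with a stated time of 72 h (on this read-out lower numbers stand for an effect already at smaller amounts and higher numbers for an effect only at larger amounts of compound), three amides sharing one core have been measured. Compound 1 `COc1cccc(OC)c1C(=O)Nc1c[nH]nc1C(=O)NC1CCC1` gives > 50000 nM, which is a limit. Compound 2 `COc1cccc(OC)c1C(=O)Nc1c[nH]nc1C(=O)NC1CCCCCC1` gives a number, 42000 nM. Compound 3 `COCCNC(=O)c1n[nH]cc1NC(=O)c1c(OC)cccc1OC` gives > 50000 nM, also a limit, and this limit is all that is known of where compound 3 stands.

Compound 4 `COc1cccc(OC)c1C(=O)Nc1c[nH]nc1C(=O)Nc1ccccn1` differs from compound 3 by pyridin-2-yl in place of 2-methoxyethyl on an amide-type nitrogen. The measured steps at this amide-type nitrogen bear on that change: an at least 1.1-fold lower number from compound 1 to compound 2 (0.07 log units; that floor lies within the scatter), an at least 1.1-fold higher number from compound 2 to compound 3 (0.07 log units; that floor lies within the scatter) and a step that the two limits leave unreadable from compound 1 to compound 3. None of them shows a change beyond the scatter, so no step beyond the scatter is expected here.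

Compound 4 is also expected to have a fair chance of reporting a limit because of the limit of > 50000 nM in this assay, at which 2 of the 3 values shown sit. The estimated step is an at least 1.1-fold lower number from compound 3 to compound 4 (0.04 log units; that floor lies within the scatter). Compound 4 is estimated at 45000 nM, with an expected range of 18000 nM to 70000 nM.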

Compound 4, half-maximal effective concentration: > 50000 nM
Compound 4 gave a limit, no number (the forecaster's own chance of this, stated with the estimate: 60%); middle value at least 1.1-fold (0.04 log units) away from the limit.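

Compound 4 shows that an aromatic ring on this amide-type nitrogen, pyridin-2-yl, also ends in a limit in this assay, so limits now hold for a ring-bearing group as well as for small rings and the open chain: the limit of > 50000 nM in this assay, at which 3 of the 4 values shown sit.
For the compounds shown here, the one readable step is an at least 1.1-fold higher number from compound 2 to compound 4 (0.07 log units; that floor lies within the scatter) and it shows no change beyond the scatter. The steps reaching compound 4 from compound 1 and from compound 3 join two limits and cannot be read.

From the compounds shown here alone, whether a carboxylic acid or a longer chain carrying an amine on this nitrogen would give a number clearly away from compound 2 stays open. Where compound 4 itself stands also stays open.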